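The compounds below may be only part of what the source reports. "The series", "measured", "known", "first", "only" and "open" are said of these compounds alone.

Compound 2, `COc1nc2ccc(Br)cc2cc1C(c1ccccc1)n1cc(-c2ccccc2C(F)(F)F)nn1`, gives 14.3% in an ADME assay on HEK293 cells (Homo sapiens) for cytotoxicity, read by sulforhodamine B assay, with a stated time of 48 h, tested at 10 uM (a higher number here means more inhibition at the concentration tested (going by the name of the read-out), a lower number less inhibition), the highest of the two numbers shown so far, while compound 1, `COc1nc2ccc(Br)cc2cc1C(c1ccccc1)n1cc(-c2ccccc2)nn1`, gives 8.25%; the step between them, a number 6.1 percentage points higher from compound 1 to compound 2 (within the scatter), is a small one. Compound 3, `COc1nc2ccc(Br)cc2cc1C(c1ccccc1)n1cc(-c2ccc(F)cc2)nn1`, differs from compound 2 as follows: 4-fluorophenyl in place of 2-(trifluoromethyl)phenyl on an aromatic carbon. For the measured compounds named here, the only measured step on this ring, a number 6.1 percentage points higher from compound 1 to compound 2 (within the scatter), stayed within the scatter, so no change beyond the scatter is expected for compound 3 in this assay. Compound 3 is therefore estimated at 10%, within 0% to 25%, an expected step of a number 4.3 percentage points lower from compound 2 to compound 3 (within the scatter).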

Compound 3, a percentage reported as inhibition, at one concentration (the size of the read-out at that concentration, not a potency): 4.04%
Beside the measured number, compound 3's estimate is 6 percentage points above it, and the stated range covers the measured number.
By their numbers in this assay, from the lowest: compounds 3, 1 and 2 (each within the scatter of the next, the first and the last beyond it).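

For the compounds shown here, with 4-fluorophenyl in place of 2-(trifluoromethyl)phenyl, this assay records a number 10.3 percentage points lower from compound 2 to compound 3 (beyond the scatter) as the first change at this position to pass the scatter. Against the unsubstituted phenyl, fluoro alone gives a number 4.2 percentage points lower from compound 1 to compound 3 (within the scatter) and so stays close to it, as trifluoromethyl did, and only the two substituted phenyl groups stand apart from each other. Nothing available accounts for the gap between them.
From the compounds shown here alone, whether an amine or a carboxylic acid on this phenyl ring would move the number further remains open. So does the effect of replacing the phenyl with a pyridine.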